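Ring size on the amide nitrogen in a dimethoxy series

The compounds below may be only part of what the source reports. "The series", "measured", "known", "first", "only" and "open" are said of these compounds alone.

Among the measured compounds shown here, the two measured members share one core. Compound 1 `COc1cc2c(cc1OC)C(CC(N)=O)CC2` carries an unsubstituted amide; in a functional assay on the whole organism (strain Wistar) for inhibition, with Rattus norvegicus as the target, read by paw edema, with stated times of 60 min and 1 h, at a dose of 100 mg/kg by the oral route (on this read-out higher numbers stand for more inhibition at the one dose given (going by the name of the read-out) and lower numbers for less inhibition), compound 1 gives 18.8%. Compound 2 `COc1cc2c(cc1OC)C(CC(=O)NC1CCCC1)CC2` has a cyclopentyl group on the amide nitrogen, and in this assay compound 2 gives 40.6%. For the measured compounds named here, compound 2 thus holds the higher of the two numbers seen so far; the one measured step is a number 21.8 percentage points higher from compound 1 to compound 2 (beyond the scatter), which is beyond the scatter and of modest size.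

Compound 3 `COc1cc2c(cc1OC)C(CC(=O)NC1CCCCC1)CC2` differs from compound 2 in a single place: cyclohexyl in place of cyclopentyl on an amide-type nitrogen. Going by the values given here, the one measured step bears on this change only loosely, since a number 21.8 percentage points higher from compound 1 to compound 2 (beyond the scatter) describes the arrival of a five-membered ring where there was none, whereas here one carbocycle is swapped for a carbocycle one carbon larger. Among the compounds with values here, no measured pair compares two ring sizes on the amide nitrogen. The step from compound 2 to compound 3 in this assay is therefore expected to lie within the scatter, a number 4.4 percentage points higher from compound 2 to compound 3 (within the scatter), with a slight lean upward. Compound 3 is estimated at 45%, between 30% and 60%.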

Compound 3, a percentage reported as inhibition, in the whole organism at one dose (the size of the read-out at that dose, not a potency): 50%
The estimate for compound 3 lay 5 percentage points below the measured number; low and high end bracket the measured number.
By their numbers in this assay, from the lowest: compound 1; then compounds 2 and 3 (each within the scatter of the next).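

In this assay, among the compounds shown here, the first direct comparison of two ring sizes on the amide-type nitrogen gives a number 9.4 percentage points higher from compound 2 to compound 3 (within the scatter) and so does not separate cyclohexyl from cyclopentyl at this position on this read-out. Against the unsubstituted amide, cyclohexyl in place of hydrogen gives a number 31.2 percentage points higher from compound 1 to compound 3 (beyond the scatter) and is a large step, so the rise seen earlier with cyclopentyl is no longer confined to a single carbocycle, though two rings on one core are all that support this. No supporting data are at hand to explain either step, and the numbers stand here only as observed differences between compounds.

The compounds shown leave open whether a carbocycle is needed at all on this nitrogen, or whether an open chain such as n-hexyl would serve as well as the cyclohexyl group. They also leave open how far the ring can be changed on the same nitrogen, for instance to cycloheptyl, to phenyl, or to a ring that carries an amine.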